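Replacing 3-methoxyphenyl with 2-methylphenyl in compound 4

A few compounds are considered here, and "the series" means these few. Any claim that something is new, unique, unknown or untested is made for them only; others in the source may bear on it.

In a functional assay on BGC-823 cells (Homo sapiens) for antiproliferative activity, read by MTT assay, with a stated time of 24 h (on this read-out lower numbers stand for stronger inhibition and higher numbers for weaker inhibition), compound 1 `O=[N+]([O-])c1ccc(CSc2nnc(-c3ccc4c(c3)OCCO4)n2-c2ccccc2)cc1` gives 48600 nM and compound 2 `Clc1cccc(CSc2nnc(-c3ccc4c(c3)OCCO4)n2-c2ccccc2)c1` gives 51200 nM. Compound 3 `COc1cccc(CSc2nnc(-c3ccc4c(c3)OCCO4)n2-c2ccccc2)c1` reads > 100000 nM, which is a limit of the assay and not a number. Compound 4 `Cc1ccccc1CSc1nnc(-c2ccc3c(c2)OCCO3)n1-c1ccccc1` carries 2-methylphenyl in place of 3-methoxyphenyl on a saturated chain carbon bound to a sulfur. For the measured compounds named here, three measured steps bear on this change: a 1.1-fold higher number from compound 1 to compound 2 (0.02 log units; within the scatter), an at least 2.0-fold higher number from compound 1 to compound 3 (0.31 log units; beyond the scatter) and an at least 1.9-fold higher number from compound 2 to compound 3 (0.29 log units; that floor lies within the scatter). None of them tests 2-methylphenyl itself. Taking compound 2 at 51200 nM as the guide, a modest move towards a lower number is expected. The expected step is an at least 1.6-fold lower number from compound 3 to compound 4 (0.22 log units; that floor lies within the scatter). Compound 4 is estimated at 60000 nM, with an expected range from 30000 nM to 100000 nM.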

Compound 4, half-maximal inhibitory concentration: > 100000 nM
Compound 4: a limit, no number (the forecaster's own chance of this, stated with the estimate: 35%); middle value at least 1.6-fold (0.22 log units) away from the limit.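

Compound 4 also stops at a limit and not a number, which places it with compound 3: the limit of > 100000 nM in this assay, at which 2 of the 4 values shown sit.

So a reading at the limit in this assay does not depend on the methoxy group, since 2-methylphenyl, which has no oxygen, gives an at least 2.0-fold higher number from compound 1 to compound 4 (0.31 log units; beyond the scatter) and an at least 1.9-fold higher number from compound 2 to compound 4 (0.29 log units; that floor lies within the scatter). The step between the two limits cannot be read.

Still open, as far as these compounds go, is how far compound 3 and compound 4 actually differ, and whether a phenyl group carrying an amine or a carboxylic acid on the saturated chain carbon bound to a sulfur would give a number.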